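From 4-methoxybenzyl to (furan-2-yl)methyl in growth inhibition

A few compounds are considered here, and "the series" means these few. Any claim that something is new, unique, unknown or untested is made for them only; others in the source may bear on it.

Within the data shown here, in a functional assay on Jurkat cells (Homo sapiens) for inhibition, read by CCK-8 assay, with a stated time of 48 h (a lower number here means a stronger inhibitor of growth, a higher number a weaker inhibitor of growth), compound 3 (`COc1ccc(CNc2nc(Nc3ccc(N4CCN(C)CC4)cn3)ncc2Cl)cc1`) gives 12900 nM as the only numerical reading so far. Compound 1 (`CN1CCN(c2ccc(Nc3ncc(Cl)c(Nc4ccccc4)n3)nc2)CC1`) is recorded at > 100000 nM which is a limit. Compound 2 (`CN1CCN(c2ccc(Nc3ncc(Cl)c(NCc4ccccc4)n3)nc2)CC1`) is recorded at > 100000 nM which is also a limit.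

Compound 4 (`CN1CCN(c2ccc(Nc3ncc(Cl)c(NCc4ccco4)n3)nc2)CC1`) is next, and the difference is furan-2-yl in place of 4-methoxyphenyl on a saturated chain carbon bound to a nitrogen on an aromatic ring with furan-2-yl in place of 4-methoxyphenyl on a saturated chain carbon bound to a nitrogen on an aromatic ring.

Among the measured compounds shown here, two measured steps bear on this change. Adding methoxy in place of hydrogen on an aromatic carbon gives an at least 7.7-fold lower number from compound 2 to compound 3 (0.88 log units; beyond the scatter) as the closest comparison. Replacing phenyl with 4-methoxybenzyl on a nitrogen on an aromatic ring gives an at least 7.7-fold lower number from compound 1 to compound 3 (0.88 log units; beyond the scatter) in the same direction. The remaining comparison is a step that the two limits leave unreadable from compound 1 to compound 2 and offers no size. For the measured compounds named here, no furan-2-yl compound has been measured yet.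

Compound 4 lacks the methoxy, as does compound 2, so a modest move to a higher number is expected. The expected change is a 3.5-fold higher number from compound 3 to compound 4 (0.54 log units; beyond the scatter) in this assay. Compound 4 could also be expected to end at the limit of > 100000 nM in this assay, at which 2 of the 3 values shown sit, with no number. For compound 4 the estimated value is 45000 nM with an expected range from 14000 nM to 100000 nM in this assay.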

Compound 4, concentration for 50% growth inhibition: > 100000 nM
Compound 4 was reported as a limit; the forecaster's own chance of this, stated with the estimate: 40%; middle value at least 2.2-fold (0.34 log units) from the limit.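

In this assay, an at least 7.7-fold higher number from compound 3 to compound 4 (0.88 log units; beyond the scatter), so on the shared core (furan-2-yl)methyl does not keep the reading that 4-methoxybenzyl gives. Both groups carry an oxygen, so an oxygen in the group on this saturated chain carbon is not enough by itself to give a numerical reading; among the compounds shown, only the 4-methoxyphenyl of compound 3 does. The steps to compound 4 from compound 1 and from compound 2 cannot be read, as both ends of each are limits, so furan-2-yl cannot be ranked against phenyl, and the series still rests on a single number: the limit of > 100000 nM in this assay, at which 3 of the 4 values shown sit.

Going by these compounds, it remains open whether the reading of compound 3 depends on the methoxy itself or would also appear with another group on the benzyl ring, such as the hydroxy of a 4-hydroxybenzyl or the chlorine of a 4-chlorobenzyl. On these data alone, it is equally open whether a methoxy or methyl group on the furan, as in a (5-methylfuran-2-yl)methyl group, would bring compound 4 back to a numerical reading.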